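Changing the Aryl Group in a Lung Cancer Cytotoxicity Series

This account rests on a few compounds, and the source may have more. Where it says the series, first, only, none or still open, it means among the compounds named here.

The three measured compounds in a functional assay on NCI-H460 cells (Homo sapiens) for cytotoxicity, read by MTT assay, with a stated time of 72 h (on this read-out lower numbers stand for stronger inhibition and higher numbers for weaker inhibition), are:
Compound 1 `COc1ccc(/C=N/NC(=O)Nc2ccc(Oc3ccnc(-c4nncn4CCN(C)C)c3)c(F)c2)c(OC)c1OC` gives 1790 nM.
Compound 2 `CN(C)CCn1cnnc1-c1cc(Oc2ccc(NC(=O)N/N=C/c3ccc(F)cc3)cc2F)ccn1` gives 1980 nM.
Compound 3 `CN(C)CCn1cnnc1-c1cc(Oc2ccc(NC(=O)N/N=C/c3cc(Br)c(O)c(Br)c3)cc2F)ccn1` gives 3760 nM.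

Compound 2 stands second highest of the three numbers. Its nearest neighbour is compound 1, the step being a 1.1-fold higher number from compound 1 to compound 2 (0.04 log units; within the scatter); the furthest is compound 3, with a 1.9-fold higher number from compound 2 to compound 3 (0.28 log units; within the scatter). The unmeasured compound 4 `COc1ccc(/C=N/NC(=O)Nc2ccc(Oc3ccnc(-c4nncn4CCN(C)C)c3)c(F)c2)cc1O` differs from compound 2 by 3-hydroxy-4-methoxyphenyl in place of 4-fluorophenyl on a carbon with a double bond to nitrogen. Two measured steps change the same aryl group: a 1.1-fold higher number from compound 1 to compound 2 (0.04 log units; within the scatter) and a 1.9-fold higher number from compound 2 to compound 3 (0.28 log units; within the scatter), both within the scatter, while a 2.1-fold higher number from compound 1 to compound 3 (0.32 log units; beyond the scatter) is only modest. All three aryl groups tried so far give similar numbers, so no step beyond the scatter is expected for compound 4 in this assay, that is a 1.1-fold higher number from compound 2 to compound 4 (0.05 log units; within the scatter). Compound 4 is therefore estimated at 2200 nM, with a range from 1100 nM to 4500 nM.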

Compound 4, half-maximal inhibitory concentration: 620 nM
The estimate for compound 4 lay 3.5-fold (0.55 log units) above the measured number, and the stated range ends above it.
By their numbers in this assay, from the lowest: compound 4; then compounds 1, 2 and 3 (each within the scatter of the next, the first and the last beyond it).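

Here (this assay) the 3-hydroxy-4-methoxyphenyl group of compound 4 gives a lower number than each of the three other aryl groups, with steps against the 4-fluorophenyl group (a 3.2-fold lower number from compound 2 to compound 4 (0.50 log units; beyond the scatter)), the 2,3,4-trimethoxyphenyl group (a 2.9-fold lower number from compound 1 to compound 4 (0.46 log units; beyond the scatter)) and the 3,5-dibromo-4-hydroxyphenyl group (a 6.1-fold lower number from compound 3 to compound 4 (0.78 log units; beyond the scatter)). The aryl group on the carbon with a double bond to nitrogen can therefore take the number below those of all three earlier compounds. Nothing available accounts for this difference.

Going by these compounds, whether the lower number needs both the hydroxy and the methoxy group stays open. So does whether an amine in place of the hydroxy group, or an ethoxy group in place of the methoxy group, would keep it.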